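The compounds below may be only part of what the source reports. "The series", "measured", "known", "first", "only" and "open" are said of these compounds alone.

Notes on the series. In a functional assay on MCF7 cells (Homo sapiens) for inhibition, read by MTT assay, with a stated time of 72 h (on this read-out lower numbers stand for stronger inhibition and higher numbers for weaker inhibition), compound 1 (`O=C1CS/C(=N\c2nc3cc(-c4ccc(Cl)cc4)sc3s2)N1`) gives 12400 nM and compound 2 (`O=C1N/C(=N/c2nc3cc(-c4ccc(Cl)cc4)sc3s2)S/C1=C/c1ccc2ccccc2c1`) gives 15200 nM on the same read-out, two values within the scatter of each other. For the measured compounds named here, compound 2 therefore stands level with the only other number available. Compound 3 (`Cc1ccc(/C=C2/S/C(=N\c3nc4cc(-c5ccc(Cl)cc5)sc4s3)NC2=O)cc1`) has 4-methylphenyl in place of naphthalen-2-yl on a double-bonded chain carbon bound to a double-bonded ring carbon. Going by the values given here, no measured pair isolates this change, so the expected size of the step rests on thin evidence. With compound 2 at 15200 nM as the anchor, a step in this assay no larger than the scatter is expected, in neither direction. The estimated 1.2-fold lower number from compound 2 to compound 3 (0.07 log units; within the scatter) stays within that scatter as well. For compound 3 the estimated value is 13000 nM (expected range 5500 nM to 30000 nM).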

Compound 3, half-maximal inhibitory concentration: 3300 nM
For compound 3 the middle estimate is 3.9-fold (0.60 log units) above the measured one; the measured number lies below the stated range.
By their numbers in this assay, from the lowest: compound 3; then compounds 1 and 2 (each within the scatter of the next).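

In this assay, the group on a double-bonded chain carbon bound to a double-bonded ring carbon can shift the read-out: 4-methylphenyl in place of naphthalen-2-yl gives a 4.6-fold lower number from compound 2 to compound 3 (0.66 log units; beyond the scatter) and so moves the number toward stronger inhibition. For the compounds shown here, the earlier compounds offered no single-place pair, so this is the first step that can be read at this position. Nothing at hand explains the step.

The change swaps two aromatic rings for one and also brings in a methyl group, and the compounds shown leave open which of these goes with the step. Also open, going by these compounds, is how the number responds at this place to plain phenyl, or to a phenyl carrying an amine or a carboxylic acid.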